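Transferring the methyl step to the ethylated core

The compounds below may be only part of what the source reports. "The series", "measured", "known", "first", "only" and "open" are said of these compounds alone.

Compound 1 `O=C1CN(C2CCCC2)c2nc(Nc3ccc(N4CCCCC4)cc3)ncc2N1` and compound 2 `CC1CCN(c2ccc(Nc3ncc4c(n3)N(C3CCCC3)CC(=O)N4)cc2)CC1` share one core; in a functional assay on HCT-116 cells (Homo sapiens) for inhibition, read by MTT assay, with a stated time of 48 h (on this read-out lower numbers stand for stronger inhibition and higher numbers for weaker inhibition), compound 1 gives 4440 nM and compound 2 gives 8430 nM. The difference between them is methyl in place of hydrogen on a saturated ring carbon, and the step it made is a 1.9-fold higher number from compound 1 to compound 2 (0.28 log units; within the scatter). Compound 3 `CCN1C(=O)CN(C2CCCC2)c2nc(Nc3ccc(N4CCCCC4)cc3)ncc21` differs from compound 1 by ethyl in place of hydrogen on an amide-type nitrogen in a ring; in this assay compound 3 gives 5470 nM, the step being a 1.2-fold higher number from compound 1 to compound 3 (0.09 log units; within the scatter). Compound 4 `CCN1C(=O)CN(C2CCCC2)c2nc(Nc3ccc(N4CCC(C)CC4)cc3)ncc21` differs from compound 3 by methyl in place of hydrogen on a saturated ring carbon, the same change as from compound 1 to compound 2, at the same place. Going by the values given here, this change occurs only twice, so the expectation rests on the single earlier step. For compound 4 the step is estimated as a 1.8-fold higher number from compound 3 to compound 4 (0.26 log units; within the scatter), because the same change earlier gave a 1.9-fold higher number from compound 1 to compound 2 (0.28 log units; within the scatter). Compound 4 is therefore expected to give about 10000 nM, between 5000 nM and 20000 nM.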

Compound 4, half-maximal inhibitory concentration: 5400 nM
Beside the measured number, compound 4's estimate is 1.9-fold (0.27 log units) above it; measured number inside the range.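

In this assay the methyl change on the core carrying ethyl gives a 1.0-fold lower number from compound 3 to compound 4 (0.01 log units; within the scatter), and its two readings do not separate: the same change on two cores in this assay, a 1.9-fold higher number (0.28 log units; within the scatter) from compound 1 to compound 2 and a 1.0-fold lower number (0.01 log units; within the scatter) from compound 3 to compound 4, 1.9-fold (0.28 log units) apart, within the scatter of two such steps. The ethyl change on the core carrying methyl gives a 1.6-fold lower number from compound 2 to compound 4 (0.19 log units; within the scatter), and its two readings do not separate either: the same change on two cores in this assay, a 1.2-fold higher number (0.09 log units; within the scatter) from compound 1 to compound 3 and a 1.6-fold lower number (0.19 log units; within the scatter) from compound 2 to compound 4, 1.9-fold (0.28 log units) apart, within the scatter of two such steps. Both changes therefore carry between these cores without a readable difference, but with every step inside the scatter, this shows neither a real effect of either change nor that the effects add up.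

Open, going by these compounds, is whether an amine or a carboxylic acid in place of the methyl would give a step beyond the scatter. The same question applies to a chain longer than ethyl on the amide-type nitrogen.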